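The source may report more compounds than this note shows. Statements on the series, on what has been measured and on what is new or still open speak of the compounds shown alone.

Going by the values given here, in a functional assay on MV4-11 cells (Homo sapiens) for antiproliferative activity, read by CCK-8 assay, with a stated time of 72 h (on this read-out lower numbers stand for stronger inhibition and higher numbers for weaker inhibition), compound 1 (`Cn1cc(-c2ccccc2Oc2ccccc2)c2cc(C(=O)NCCCCCCC(=O)NO)[nH]c2c1=O`) gives 180 nM as the lower of the two numbers so far, and compound 2 (`Cc1cc(F)cc(C)c1Oc1ccc(C(C)(C)O)cc1-c1cn(C)c(=O)c2[nH]c(C(=O)NCc3ccc(C(=O)NO)cc3)cc12`) gives 440 nM as the higher one, a gap beyond the usual scatter. Compound 3 (`Cn1cc(-c2ccccc2Oc2ccccc2)c2cc(C(=O)NCCCC(=O)NO)[nH]c2c1=O`) keeps the core of compound 1 but has a shorter chain (hydroxycarbamoyl in place of 3-(hydroxycarbamoyl)propyl on a saturated chain carbon, three bonds along the chain from an amide-type nitrogen), with hydroxycarbamoyl in place of 3-(hydroxycarbamoyl)propyl on a saturated chain carbon, three bonds along the chain from an amide-type nitrogen. Among the compounds with values here, no measured pair tests chain length, so the expectation rests on judgement alone. In this assay a weakening beyond the scatter is expected, estimated as an 8.3-fold higher number from compound 1 to compound 3 (0.92 log units; beyond the scatter) for this shortening. The estimated value for compound 3 is 1500 nM (range 400 nM to 6000 nM).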

Compound 3, half-maximal inhibitory concentration: 380 nM
Compound 3: middle estimate off by 3.9-fold (0.60 log units), on the high side; the measured number lies below the stated range.
By their numbers in this assay, from the lowest: compound 1; then compounds 3 and 2 (each within the scatter of the next).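

In this assay, going from 6-(hydroxycarbamoyl)hexyl to 3-(hydroxycarbamoyl)propyl on the shared core gives a 2.1-fold higher number from compound 1 to compound 3 (0.32 log units; beyond the scatter). Going by these compounds alone, this is the first one-place comparison here, and it shows that chain length at this position changes the read-out, though only modestly. Nothing measured here explains the step. On these data alone, whether a longer chain than 6-(hydroxycarbamoyl)hexyl, or one of intermediate length, would give a lower number stays open. So does the effect of a carboxylic acid in place of the hydroxycarbamoyl end.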